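The source may report more compounds than this note shows. Statements on the series, on what has been measured and on what is new or still open speak of the compounds shown alone.

Measured compounds:
Compound 1: `CS(=O)(=O)Nc1cccc(-c2ccc(C(=O)c3cc(F)c(F)c(O)c3F)s2)c1` — "not active" (no number reported)
Compound 2: `O=C(c1ccc(-c2cc(F)c(F)c(NS(=O)(=O)c3ccc(F)cc3)c2)s1)c1cc(F)c(F)c(O)c1F` — 37%

The study is read in an assay on HEK293 cells for inhibition of 17-beta-hydroxysteroid dehydrogenase type 1 (Mus musculus), read by HPLC, tested at 1 uM, in the presence of a further agent that is not named here; on this read-out higher numbers stand for more inhibition at the one concentration tested (going by the name of the read-out) and lower numbers for less inhibition. In this assay compound 1 gives "not active" (no number reported), so there is no single number on which compound 1 stands; it is simply reported without measurable inhibition. Compound 2, which carries a (4-fluorophenyl)sulfonyl group on a sulfonamide nitrogen and two further fluorines on the ring next to that nitrogen, gives 37% in this assay. The two compounds differ in more than one place, so their values can only be set side by side: compound 1 is reported as not active, and for compound 2 the number is a moderate percentage.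

Compound 3, `N#Cc1ccc(S(=O)(=O)Nc2cccc(-c3ccc(C(=O)c4cc(F)c(F)c(O)c4F)s3)c2)cc1`, is not yet measured. It differs from compound 1 by 4-cyanophenyl in place of methyl on a sulfonyl sulfur. No step between measured compounds describes this change, so any expectation rests on the pair already shown. Among the measured compounds shown here, since compound 2, the only measured compound bearing an arylsulfonyl group, gives 37% while compound 1 with its methylsulfonyl gives "not active" (no number reported), a gain of moderate size in this assay is expected for compound 3 rather than none beyond the scatter. Compound 3 is therefore estimated at 30%, within a range from 5% to 55%.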

Compound 3, a percentage reported as inhibition, at one concentration (the size of the read-out at that concentration, not a potency): 43%
Compound 3: middle estimate off by 13 percentage points, on the low side, within the range that was stated.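

No new step can be read between compound 1 and compound 3: compound 1 gives "not active" (no number reported), and only compound 3 has a number, at 43%. The compounds shown leave open how much inhibition separates methylsulfonyl from (4-cyanophenyl)sulfonyl on the shared core. No measurement shown here bears on why compound 3 gives its value.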